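This account rests on a few compounds, and the source may have more. Where it says the series, first, only, none or still open, it means among the compounds named here.

In a functional assay on A549 cells (Homo sapiens) for cytotoxicity (a lower number here means a stronger inhibitor, a higher number a weaker inhibitor), compound 1 `C#C[C@H](O)/C=C/CCCCCCCCC/C=C\CCCCCCCCC/C=C/[C@@H](O)C#C` gives 160 nM, compound 2 `C#C[C@H](O)/C=C/CCCCCCCCC/C=C\CCCCCCCCCCC/C=C/[C@@H](O)C#C` gives 160 nM and compound 3 `C#C[C@H](O)/C=C/CCCCC/C=C\CCCC/C=C\CCCCCCCCC/C=C/[C@@H](O)C#C` gives 160 nM, so compound 3 stands level with the other two. Compound 4 `C#C[C@H](O)/C=C/CCCCCCCCC/C=C\CCCC/C=C\CCCCCCCCC/C=C/[C@@H](O)C#C` carries one structural change relative to compound 3: a group of 10 heavy atoms (9 carbon, 1 oxygen; no ring) in place of a group of 6 heavy atoms (5 carbon, 1 oxygen; no ring), on a saturated chain carbon, five bonds along the chain from a double-bonded chain carbon. Going by the values given here, one measured step bears on this, since it also places a larger group on a saturated chain carbon. That step, no change at the digits printed from compound 1 to compound 2 (within the scatter), stays within the scatter. The group entering here is larger than in that step, so the precedent is only partial. Even so, no step beyond the scatter is expected in this assay, in either direction. The expected step is no change at the digits printed from compound 3 to compound 4 (within the scatter). For compound 4 the estimated value is 160 nM, with an expected range of 80 nM to 320 nM.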

Compound 4, half-maximal inhibitory concentration: 160 nM
The estimate for compound 4 equals the measured number at the digits printed; the measured number falls inside the stated range.
By their numbers in this assay, from the lowest: compounds 1, 2, 3 and 4 (each within the scatter of the next).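

In this assay the step of no change at the digits printed from compound 3 to compound 4 (within the scatter) shows that, on a saturated chain carbon, five bonds along the chain from a double-bonded chain carbon, a group of 10 heavy atoms can replace one of 6 heavy atoms without a measurable shift. The earlier step, no change at the digits printed from compound 1 to compound 2 (within the scatter), involved a smaller enlargement at a different place. No supporting data offer a cause for this flat result. On these data alone, whether a much longer chain would also leave the value unchanged remains open, as does the effect of an amine or a carboxylic acid at this place.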